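This account rests on a few compounds, and the source may have more. Where it says the series, first, only, none or still open, it means among the compounds named here.

Measured so far:
Compound 1, `C=Cc1cccc(-c2[nH]c3cc(OC)ccc3c(=O)c2C(=O)OCC)c1`: > 21500 nM
Compound 2, `CCOC(=O)c1c(-c2cccc(-c3ccccc3)c2)[nH]c2cc(OC)ccc2c1=O`: > 21500 nM

In an ADME assay on BJ cells (Homo sapiens) for cytotoxicity, read by luminescence, with a stated time of 72 h (a higher number here means that more compound is needed for the effect, a lower number that less compound is needed), compound 1 gives > 21500 nM, which is a limit of the assay rather than a number. Compound 2 likewise reaches only a limit in this assay, > 21500 nM. The two compounds differ in one place, phenyl in place of vinyl on an aromatic carbon, and the step that the two limits leave unreadable from compound 1 to compound 2 therefore cannot be read in size or direction. the limit of > 21500 nM in this assay, at which 2 of the 2 values shown sit, sums up the whole of what is known: every value shown is a limit, so compound 2 stands at that limit and nowhere more exact.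

Compound 3, `CCOC(=O)c1c(-c2cccc(NC(C)=O)c2)[nH]c2cc(OC)ccc2c1=O`, is not yet measured. It arises from compound 2 by acetamido in place of phenyl on an aromatic carbon, the new group sitting meta to a large group. No measured step bears on this particular change, and the one step shown is unreadable, so the data give no direction to expect beyond the scatter. Compound 3 is expected to stay at the limit as well, a step that the limit leaves unreadable from compound 2 to compound 3. The estimate for compound 3 in this assay is 30000 nM, with a range from 12000 nM to 80000 nM.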

Compound 3, half-maximal effective concentration: > 21500 nM
Compound 3 ended at the assay's limit (the forecaster's own chance of this, stated with the estimate: 80%); the middle value does not contradict the limit.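

Compound 3 gives > 21500 nM in this assay as a limit of the assay, not a number, so the steps to it from compound 1 and compound 2 cannot be read in size or direction. The compounds shown leave open how much of each is needed for the effect, and whether vinyl, phenyl or acetamido on that aromatic carbon changes it at all.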